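The compounds below may be only part of what the source reports. "The series", "measured", "known", "first", "only" and "open" are said of these compounds alone.

Measured values in an ADME assay on L6 cells (Rattus norvegicus) for cytotoxicity (on this read-out lower numbers stand for stronger inhibition and higher numbers for weaker inhibition), are as follows.

- Compound 1 (`O=C(CN1CCN(c2ccc(C(F)(F)F)cc2)CC1)N1CCN(c2ccc(C(F)(F)F)cc2)CC1`) gives (31700 nM)
- Compound 2 (`Cc1ccc(N2CCN(C(=O)Cn3cnc([N+](=O)[O-])n3)CC2)cc1`) gives (148000 nM)
- Compound 3 (`O=C(CN1CCN(c2ccc(Cl)c(Cl)c2)CC1)N1CCN(c2ccc(Cl)c(Cl)c2)CC1`) gives (20200 nM)

Compound 2 has the highest number of the three, and its gaps to compound 1 and compound 3 both lie beyond the usual scatter. Compound 4 (`O=C(Cn1cnc([N+](=O)[O-])n1)N1CCN(c2ccc(Cl)c(Cl)c2)CC1`) differs from compound 2 in one place, with 3,4-dichlorophenyl in place of 4-methylphenyl on an amine nitrogen in a ring. For the measured compounds named here, no measured pair isolates this change, so the expectation rests on thin evidence. Compound 3 also carries 3,4-dichlorophenyl and gives (20200 nM) in a lower range, but it differs from compound 2 elsewhere as well. Only part of that gap is therefore expected to carry over. The expected step of a 2.5-fold lower number from compound 2 to compound 4 (0.39 log units; beyond the scatter) is a moderate one toward a lower number in this assay and only just beyond the scatter. Compound 4 is estimated at 60000 nM with an expected range from 20000 nM to 140000 nM once it is measured.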

Compound 4, half-maximal inhibitory concentration: 108000 nM
Estimate against measurement, compound 4: 1.8-fold (0.26 log units) below, and the stated range covers the measured number.
By their numbers in this assay, from the lowest: compounds 3 and 1 (each within the scatter of the next); then compounds 4 and 2 (each within the scatter of the next).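

In this assay, for the compounds shown here, the pair of compound 2 and compound 4 is the first to isolate this change on the amine nitrogen in the ring, and it gives a 1.4-fold lower number from compound 2 to compound 4 (0.14 log units; within the scatter). At this position on the shared core, 3,4-dichlorophenyl and 4-methylphenyl therefore cannot be told apart in this assay, although this rests on a single pair. Nothing measured alongside these compounds accounts for this result.

As far as these compounds go, it remains open whether a different group at this position, such as a benzyl group or a phenyl ring bearing a carboxylic acid, would move the number beyond the scatter. The compounds shown also leave open whether the same exchange would give a similar step on the core of compound 3.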